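The source may hold more compounds than are shown below. What is called first, only, known or untested is meant among the compounds shown, and "the series" means these compounds.

Measured so far, in an assay on MCF7 cells for inhibition of Steryl-sulfatase (Homo sapiens), read by scintillation counting, with a stated time of 5 h, tested at 0.1 uM; on this read-out lower numbers stand for a weaker effect and higher numbers for a stronger effect at the one concentration tested:
- compound 1, `CCC(CC)(c1ccc(OS(N)(=O)=O)c(C)c1)c1ccc(OS(N)(=O)=O)c(C)c1`, gives < 10%, which is a limit of the assay rather than a number.
- compound 2, `C[Si](C)(c1ccc(OS(N)(=O)=O)cc1)c1ccc(OS(N)(=O)=O)cc1`, gives 35.8%.
- compound 3, `NS(=O)(=O)Oc1ccc(Sc2ccc(OS(N)(=O)=O)cc2)cc1`, gives 57.1%.

All three compounds carry two aryl sulfamate groups on a shared two-ring layout; they differ in the atom or group that links the two rings and in the presence of methyl groups on the rings. Among the two actual numbers, compound 2 stands lowest: compound 3 lies above it by a gap beyond the scatter, and the third value is only a limit.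

Among the measured compounds shown here, compound 4, `C[Si](C)(c1ccc(O)cc1)c1ccc(OS(N)(=O)=O)cc1`, is the one compound here that has not yet been measured. It keeps the silicon-based linker of compound 2 and changes one end only: hydrogen in place of sulfamoyl on an oxygen on an aromatic ring. One of the two sulfamate groups is thus gone, and a hydroxy group remains in its place.

For the measured compounds named here, no measured pair here shows a single change of this kind, so the size of the step rests on judgement. In this assay the step from compound 2 to compound 4 is expected to go downward, probably beyond the scatter, since only one sulfamate is left. For compound 4 the expected inhibition is 15%, within a range from 0% to 38%, and the step of a number 20.8 percentage points lower from compound 2 to compound 4 (beyond the scatter) is what this estimate means.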

Compound 4, a percentage reported as inhibition, at one concentration (the size of the read-out at that concentration, not a potency): 25.2%
Compound 4: the middle estimate sits 10.2 percentage points below what was measured; low and high end bracket the measured number.
By their numbers in this assay, from the lowest: compound 4; then compound 2; then compound 3. At a limit, below all of these: compound 1.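

In this assay, among the compounds shown here, the change from sulfamoyloxy to hydroxy gives the first direct reading of what one of the two sulfamate ends contributes, with a number 10.6 percentage points lower from compound 2 to compound 4 (beyond the scatter). The step is modest, which shows that a compound with a single sulfamate and a hydroxy group at the other end still gives a measurable effect at this one concentration, so the second sulfamate is not needed for inhibition to be seen. The value of compound 4 is an actual number rather than a limit, so the full size of the step can be read: the limit of < 10% in this assay, at which 1 of the 4 values shown sits.

The compounds shown include none with a methoxy group or an amine on that oxygen's ring position, or with a bare ring hydrogen there, so the loss of the sulfamoyl group cannot be separated from the gain of the hydroxy group. Going by these compounds, it also remains open whether the same change would give a step of similar size on the sulfur-linked compound 3, and a reading at one concentration says nothing about the potency of either compound.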